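Removing the Phenyl Group from Compound 2

The source may hold more compounds than are shown below. What is called first, only, known or untested is meant among the compounds shown, and "the series" means these compounds.

Compound 1, `COc1ccc(C(=O)/C=C/c2ccc(F)cc2)c2c1C=CC(C)(C)O2`: in a functional assay on SW-620 cells (Homo sapiens) for antiproliferative activity, read by MTT assay, with a stated time of 24 h (on this read-out lower numbers stand for stronger inhibition and higher numbers for weaker inhibition), compound 1 gives > 10000 nM, which is a limit of the assay.
Compound 2, `COc1ccc(C(=O)/C=C/c2ccc(-c3ccccc3)cc2)c2c1C=CC(C)(C)O2`: in this assay compound 2 gives > 10000 nM, which is again a limit of the assay.

Compound 2 therefore stands at the limit, and it is not alone there: the limit of > 10000 nM in this assay, at which 2 of the 2 values shown sit. Going by the values given here, the one measured step, a step that the two limits leave unreadable from compound 1 to compound 2, is closed by the two limits, so its size and direction cannot be read.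

Compound 3, `COc1ccc(C(=O)/C=C/c2ccccc2)c2c1C=CC(C)(C)O2`, has not been measured in this assay. It differs from compound 2 in one place: hydrogen in place of phenyl on an aromatic carbon. Among the compounds with values here, the only measured step that bears on this change is the one from compound 1 to compound 2, and since that step is unreadable, it gives no size to carry over and no direction beyond the scatter. What the data show is that neither measured compound reaches a number in this assay, and the change back to a bare aromatic carbon gives no ground to expect a departure from that.

Compound 3 is therefore expected to sit near the limit as well, with an estimate of 15000 nM in this assay and a range from 4000 nM to 60000 nM. The expected step is a step that the limit leaves unreadable from compound 2 to compound 3.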

Compound 3, half-maximal inhibitory concentration: > 10000 nM
Compound 3 was reported as a limit (the forecaster's own chance of this, stated with the estimate: 75%); the middle value lies beyond the limit too.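

No new step can be read among compound 1, compound 2 and compound 3, since all three are reported only as limits: the limit of > 10000 nM in this assay, at which 3 of the 3 values shown sit.

The compounds shown leave open whether fluoro, phenyl or hydrogen on that aromatic carbon makes any difference in this assay, and what number, if any, each compound would give there.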